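Shortening a chain, watching for cytotoxicity

This account rests on a few compounds, and the source may have more. Where it says the series, first, only, none or still open, it means among the compounds named here.

Compound 2 `CCCCCCCCCc1cc2cn(COCCO)c(O)nc-2n1` is one of three compounds tested in a functional assay on HEL cells (Homo sapiens), read by microscopy; a lower number here means that less compound is tolerated, a higher number that more compound is tolerated. There compound 2 gives only a limit, > 80000 nM. Compound 1 `CCCCc1cc2cn(COCCO)c(=O)nc2o1` likewise gives a limit, > 400000 nM. Compound 3 `CO[C@H]1[C@H](O)[C@@H](O)[C@@H](O)O[C@@H]1C(=O)O` also reaches only a limit, > 100000 nM. Among the measured compounds shown here, none of the three yields a measured number, so compound 2 stands at a limit alongside the other two, and no step between measured compounds can be read off. Compound 4 `CCCCCc1cc2cn(COCCO)c(O)nc-2n1` differs from compound 2 by hydrogen in place of butyl on a saturated chain carbon, five bonds along the chain from an aromatic carbon. For the measured compounds named here, with no measured step to lean on, the step expected here is a step that the limit leaves unreadable from compound 2 to compound 4, nothing beyond the usual scatter. Compound 4 is therefore estimated at 100000 nM, within 40000 nM to 400000 nM, and most likely again only a limit.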

Compound 4, minimum cytotoxic concentration: > 400000 nM
Compound 4 ended at the assay's limit; the forecaster's own chance of this, stated with the estimate: 85%; middle value at least 4.0-fold (0.60 log units) away from the limit.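

Compound 2 and compound 4 both give only limits rather than numbers, so no step can be read between them. The compounds shown leave open at what concentration any of them harms the cells, and whether chain length changes that.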